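This account rests on a few compounds, and the source may have more. Where it says the series, first, only, none or still open, it means among the compounds named here.

Compound 1 `COc1cc(/C=C/C(=O)c2cccc(-n3cc(-c4ccc(Cl)cc4)[nH]c3=O)c2)ccc1O` carries a chloro group on one of its aromatic rings and a trimethoxy-free phenol at the other end of the chalcone-like chain. In a functional assay on NCI-H23 cells (Homo sapiens) for inhibition (on this read-out higher numbers stand for weaker inhibition of growth and lower numbers for stronger inhibition of growth), compound 1 gives 3180 nM, the highest of the two numbers recorded. For the measured compounds named here, compound 2 `COc1cc(/C=C/C(=O)c2cccc(-n3cc(-c4ccccc4)[nH]c3=O)c2)cc(OC)c1OC` differs from it in more than one place, so no single step can be drawn between them; in this assay compound 2 gives 1430 nM, a lower number than compound 1 by a margin that lies beyond the usual scatter.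

Compound 3 `COc1cc(/C=C/C(=O)c2cccc(-n3cc(-c4ccccc4)[nH]c3=O)c2)ccc1O` has not been measured in this assay. Compared with compound 1, the change is hydrogen in place of chloro on an aromatic carbon. Going by the values given here, no measured pair shows this exact change, so the size of its effect is unknown. Compound 2, which also bears an unsubstituted phenyl, gives the lower number, but it differs from compound 3 elsewhere as well, so that comparison carries little weight. The step expected from this change is a 1.1-fold higher number from compound 1 to compound 3 (0.04 log units; within the scatter), likely small and possibly none beyond the scatter. Compound 3 is estimated at 3500 nM, within a range from 1200 nM to 9000 nM.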

Compound 3, concentration for 50% growth inhibition: 2020 nM
The estimate for compound 3 lay 1.7-fold (0.24 log units) above the measured number; low and high end bracket the measured number.
By their numbers in this assay, from the lowest: compounds 2, 3 and 1 (each within the scatter of the next, the first and the last beyond it).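

With a 1.6-fold lower number from compound 1 to compound 3 (0.20 log units; within the scatter) in this assay, the change from 4-chlorophenyl to phenyl has its first measured size, and that size does not separate the two compounds. At this place, on an aromatic carbon para to a large group, chloro gives way to hydrogen without a difference that stands out from repeated measurements, although this rests on a single pair with the rest of the structure held fixed. Nothing available here speaks to why the step has this size.

The compounds shown leave open whether another group at this place, such as fluoro, an amine or a carboxylic acid, would move the number beyond the scatter; chloro and hydrogen are the only two seen there. They also leave open whether the same change would give a step of similar size with the end of the chain carried by compound 2, which has no chloro partner among them.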